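Swapping a Diamine Ring for Chloro on the Shared Core

The source may hold more compounds than are shown below. What is called first, only, known or untested is meant among the compounds shown, and "the series" means these compounds.

Measured compounds:
compound 1 `O=C(Nc1ccc(-c2cnc3cc(N4CCN(C5CC5)CC4)ccn23)cc1)c1ccc([N+](=O)[O-])o1`: 1920 nM
compound 2 `CN1CCCN(c2ccn3c(-c4ccc(NC(=O)c5ccc([N+](=O)[O-])o5)cc4)cnc3c2)CC1`: 2700 nM

Both compounds were tested in a functional assay on AGS cells (Homo sapiens) for antiproliferative activity, read by CCK-8 assay, with a stated time of 72 h; on this read-out lower numbers stand for stronger inhibition and higher numbers for weaker inhibition. Compound 1 and compound 2 sit side by side: the step of a 1.4-fold higher number from compound 1 to compound 2 (0.15 log units; within the scatter) lies within the scatter, so neither can be set apart from the other, and compound 1 is simply one of two nearly equal numbers.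

Compound 3 `O=C(Nc1ccc(-c2cnc3cc(Cl)ccn23)cc1)c1ccc([N+](=O)[O-])o1` has not yet been measured. It differs from compound 1 in one place: chloro in place of 4-cyclopropylpiperazin-1-yl on an aromatic carbon. Among the measured compounds shown here, the only measured step exchanges one diamine ring for another on the same aromatic carbon and changes nothing beyond the scatter; it does not show what happens when the ring is taken away altogether and a single chlorine atom stands in its place. There is therefore no direct guide, and the expectation must stay wide. A modest move toward weaker inhibition seems somewhat more likely than a gain, but a flat result is entirely possible.

The step from compound 1 to compound 3 is expected to be a 1.8-fold higher number from compound 1 to compound 3 (0.26 log units; within the scatter). For compound 3 the estimated value in this assay is 3500 nM, within a range from 900 nM to 14000 nM.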

Compound 3, half-maximal inhibitory concentration: 1700 nM
Compound 3: the middle estimate sits 2.1-fold (0.31 log units) above what was measured; low and high end bracket the measured number.
By their numbers in this assay, from the lowest: compounds 3, 1 and 2 (each within the scatter of the next).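

In this assay, replacing the whole 4-cyclopropylpiperazin-1-yl group with a single chlorine atom gives a 1.1-fold lower number from compound 1 to compound 3 (0.05 log units; within the scatter). The same exchange starting from 4-methyl-1,4-diazepan-1-yl gives a 1.6-fold lower number from compound 2 to compound 3 (0.20 log units; within the scatter), so the earlier finding that one diamine ring can stand in for another now extends further: on this aromatic carbon, among these three compounds, the read-out does not depend on having a diamine ring at all, and even a far smaller group leaves the number within the scatter. No supporting measurements are available to explain why this position tolerates so large a change in size.

The compounds shown leave open whether any group on this carbon can move the number beyond the scatter, for instance a primary amine, a carboxylic acid or a plain hydrogen atom. Going by these compounds, all three also share everything outside this position, so it remains unknown whether the same tolerance would hold if the shared core were altered.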